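Replacing isopropyl with 4-fluorobenzyl in compound 1

The compounds below may be only part of what the source reports. "The series", "measured", "known", "first", "only" and "open" are said of these compounds alone.

Measured in an ADME assay on HEK-293T cells (Homo sapiens) for inhibition, read by luminescence, with a stated time of 72 h, tested at 5 uM; a lower number here means less inhibition of growth, a higher number more inhibition of growth at the concentration tested:
Compound 1 `C=CS(=O)(=O)NC/C=C/c1cc(OC)cc(O)c1C(=O)OC(C)C` gives 0.1%
Compound 2 `COc1cc(O)c(C(=O)OC(C)C)c(/C=C/CN2C(=O)C=CC2=O)c1` gives 8%

For the measured compounds named here, compound 1 has only one measured neighbour, and their two values do not separate. Going by the values given here, the one measured step is a number 7.9 percentage points higher from compound 1 to compound 2 (within the scatter). Compound 3 `C=CS(=O)(=O)NC/C=C/c1cc(OC)cc(O)c1C(=O)OCc1ccc(F)cc1` keeps the core of compound 1 and alters one group: 4-fluorobenzyl in place of isopropyl on an oxygen next to a carbonyl group. This puts 4-fluorobenzyl in place of isopropyl on an oxygen next to a carbonyl group. Among the compounds with values here, the measured step changed a different place, a saturated chain carbon, so no measurement yet tests this oxygen. That step offers only indirect guidance, and it stayed within the scatter. The expected change is therefore small, and no shift beyond the scatter is anticipated: the estimated step is a number 5.9 percentage points higher from compound 1 to compound 3 (within the scatter). For compound 3 the estimate is 6%, with an expected range from 0% to 22%.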

Compound 3, percent growth inhibition at one concentration: 0%
Compound 3: the middle estimate sits 6 percentage points above what was measured; measured number inside the range.
By their numbers in this assay, from the lowest: compounds 3, 1 and 2 (each within the scatter of the next).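

The earlier compounds shown here tested only a saturated chain carbon. For the compounds shown here, at the oxygen next to a carbonyl group, the first reading in this assay for 4-fluorobenzyl in place of isopropyl is a number 0.1 percentage points lower from compound 1 to compound 3 (within the scatter), so this larger group, with its six-membered aromatic ring, does not separate from isopropyl in this measurement. No available evidence explains this reading.

What the compounds shown leave open is whether a different group on this oxygen, such as a longer alkyl chain or one carrying an amine, would move the number in this assay beyond the scatter. Also open, on these data alone, is how 4-fluorobenzyl would read when combined with the group that compound 2 carries on the saturated chain carbon.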